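This account rests on a few compounds, and the source may have more. Where it says the series, first, only, none or still open, it means among the compounds named here.

Measured compounds:
compound 1, `CN1CCN(CCCN(C[C@H]2Cc3ccccc3CN2)[C@H]2CCCc3cccnc32)CC1` — 125 nM
compound 2, `c1ccc2c(c1)CN[C@H](CN(CCCN1CCNCC1)[C@H]1CCCc3cccnc31)C2` — 1150 nM
compound 3, `c1ccc2c(c1)CN[C@@H](CN(CCCCN1CCNCC1)[C@H]1CCCc3cccnc31)C2` — 66 nM

In a functional assay on CCRF-CEM cells for antagonist activity at C-X-C chemokine receptor type 4 (Homo sapiens), read by calcium flux, with stated times of 25 min and 90 s (on this read-out lower numbers stand for stronger inhibition and higher numbers for weaker inhibition), compound 2 gives the highest number of the three; the values of compound 1 and compound 3 both lie lower by margins beyond the scatter. Compound 4, `c1cnc2c(c1)CN[C@@H](CN(CCCN1CCNCC1)[C@H]1CCCc3cccnc31)C2`, differs from compound 2 by a group of 10 heavy atoms (8 carbon, 2 nitrogen; one six-membered non-aromatic ring with 1 hetero atom, one six-membered aromatic ring with 1 hetero atom) in place of a group of 10 heavy atoms (9 carbon, 1 nitrogen; one six-membered non-aromatic ring with 1 hetero atom, one six-membered aromatic ring of carbon only), on a saturated chain carbon bound to an amine nitrogen. Within the data shown here, the only measured step, a 1.9-fold lower number from compound 1 to compound 3 (0.28 log units; within the scatter), concerns the piperazine end of the chain and does not touch the ring pair exchanged here, so no measured step bears on this change. With nothing to anchor a direction, no step beyond the scatter is expected. Compound 4 is therefore estimated at 1100 nM in this assay, with a range of 300 nM to 4000 nM, corresponding to an expected step of a 1.0-fold lower number from compound 2 to compound 4 (0.02 log units; within the scatter).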

Compound 4, half-maximal inhibitory concentration: 171 nM
The estimate for compound 4 lay 6.4-fold (0.81 log units) above the measured number, and the stated range ends above it.
By their numbers in this assay, from the lowest: compounds 3, 1 and 4 (each within the scatter of the next, the first and the last beyond it); then compound 2.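

In this assay, the ring pair on a saturated chain carbon bound to an amine nitrogen proves to matter: replacing 1,2,3,4-tetrahydroisoquinolin-3-yl with the group whose aromatic ring holds a hetero atom gives a 6.7-fold lower number from compound 2 to compound 4 (0.83 log units; beyond the scatter) in this series. Among these compounds, this is the first measured step at this place, as the earlier step concerned only the piperazine end of the chain. No available evidence accounts for the step.

As far as these compounds go, whether a fluorine or a methoxy group on the entering aromatic ring would give a similar number remains open. So does the effect of a longer chain on compound 4.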